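The source may report more compounds than this note shows. Statements on the series, on what has been measured and on what is new or still open speak of the compounds shown alone.

Going by the values given here, compound 1 `COc1ccc2c(c1)[n+]([O-])nc(NCOC(C)c1ccccc1)[n+]2[O-]` is one of three compounds measured in a functional assay on KB cells (Homo sapiens) for cytotoxicity, read by MTT assay, with a stated time of 72 h; a lower number here means a stronger inhibitor, a higher number a weaker inhibitor. In this assay compound 1 gives 12400 nM, the lowest of the three numbers, though both other numbers lie within the scatter of it. Compound 2 `[O-][n+]1nc(NCOC2CCCCC2)[n+]([O-])c2ccccc21` gives 22100 nM in this assay, and compound 3 `CCOCNc1n[n+]([O-])c2ccccc2[n+]1[O-]` gives 22500 nM. Among the compounds with values here, the only step between measured compounds that differ in a single place is the one from compound 2 to compound 3, ethyl in place of cyclohexyl on an oxygen on a saturated carbon.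

Compound 4 `CCCCCOCNc1n[n+]([O-])c2cc(OC)ccc2[n+]1[O-]` has not yet been measured in this assay. Its difference from compound 1 is pentyl in place of 1-phenylethyl on an oxygen on a saturated carbon. That one measured step bears on it most closely, because a 1.0-fold higher number from compound 2 to compound 3 (0.01 log units; within the scatter) concerns the same kind of exchange, a ring-bearing group giving way to a chain on an oxygen on a saturated carbon. Within the data shown here, no measured pair separates a phenyl-bearing group from a pentyl chain at this position, so the expectation rests on that single step. Compound 4 is therefore expected to sit close to compound 1, with a 1.2-fold higher number from compound 1 to compound 4 (0.08 log units; within the scatter) expected to remain within the scatter. The estimate for compound 4 is 15000 nM, with a range from 6000 nM to 40000 nM.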

Compound 4, half-maximal inhibitory concentration: 17000 nM
Compound 4: the middle estimate sits 1.1-fold (0.05 log units) below what was measured, within the range that was stated.
By their numbers in this assay, from the lowest: compounds 1, 4, 2 and 3 (each within the scatter of the next).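

In this assay, pentyl in place of 1-phenylethyl gives a 1.4-fold higher number from compound 1 to compound 4 (0.14 log units; within the scatter) and so stays within the scatter. This shows that, on the core of compound 1, a six-membered aromatic ring of carbon only can leave this place, on an oxygen on a saturated carbon, and that the group can go from 8 heavy atoms to 5 without a change that can be read in this assay. The earlier step (a 1.0-fold higher number from compound 2 to compound 3 (0.01 log units; within the scatter)) showed the same outcome only for cyclohexyl giving way to ethyl on a different core, so the two steps now agree across both cores and for a group with an aromatic ring as well as one with a saturated ring.

The compounds shown leave open whether an amine, a carboxylic acid or a much longer chain such as dodecyl on this oxygen would carry the number beyond the scatter. No measurement is available that explains why these exchanges leave the number within the scatter.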